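This account rests on a few compounds, and the source may have more. Where it says the series, first, only, none or still open, it means among the compounds named here.

- compound 1 `COc1ccc(/C=C/C(=O)/C=C/c2nc(C)c(C)nc2C)cc1` gives 3500 nM
- compound 2 `COc1ccc(/C=C/C(=O)/C=C/c2nc(C)c(C)nc2C)cc1OC` gives 3790 nM
- compound 3 `COc1ccc(/C=C/C(=O)/C=C/c2nc(C)c(C)nc2C)c(OC)c1` gives 3070 nM

These values come from a functional assay on A549 cells (Homo sapiens) for antiproliferative activity, read by MTT assay, with a stated time of 72 h; on this read-out lower numbers stand for stronger inhibition and higher numbers for weaker inhibition. Compound 1 stands close to both of the others, as the two measured steps show: a 1.1-fold higher number from compound 1 to compound 2 (0.03 log units; within the scatter) and a 1.1-fold lower number from compound 1 to compound 3 (0.06 log units; within the scatter). Neither step leaves the usual scatter.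

The next compound, compound 4 `Cc1nc(C)c(/C=C/C(=O)/C=C/c2ccc(C(F)(F)F)cc2)nc1C`, changes the same aromatic ring of compound 1 in a different way: trifluoromethyl in place of methoxy on an aromatic carbon. The two measured steps bear on this only indirectly. Each adds a further methoxy group to that ring, but neither removes the existing methoxy group or brings in trifluoromethyl. They show that these additions left the number within the scatter, but they cannot show what this replacement will do. No step beyond the scatter is therefore expected in this assay, and this expectation is held loosely. The expected change is no change at the digits printed from compound 1 to compound 4 (within the scatter). For compound 4 the estimated value is 3500 nM, with an expected range from 1500 nM to 8000 nM.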

Compound 4, half-maximal inhibitory concentration: 11700 nM
Compound 4: the middle estimate sits 3.3-fold (0.52 log units) below what was measured, and the stated range ends below it.
By their numbers in this assay, from the lowest: compounds 3, 1 and 2 (each within the scatter of the next); then compound 4.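

In this assay, for the compounds shown here, trifluoromethyl in place of methoxy gives a 3.3-fold higher number from compound 1 to compound 4 (0.52 log units; beyond the scatter), the first step in this set to leave the usual scatter. Adding a further methoxy group to the ring left the number within the scatter, whereas replacing the methoxy group at this place, para to a large group, weakens inhibition modestly, so the number does respond to the group that stands here. Nothing measured here accounts for this loss of activity.

The compounds shown leave open how an amine, a hydroxyl group or a carboxylic acid at this place would compare, and whether any group there could improve on compound 1 at 3500 nM. They also leave open whether the same replacement would have a similar effect on a different core.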